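The source may report more compounds than this note shows. Statements on the series, on what has been measured and on what is new or still open speak of the compounds shown alone.

Of the compounds shown here, three built on one shared core have been measured in an ADME assay on MT4 cells (Homo sapiens) for cytotoxicity, read by MTT assay; a lower number here means that less compound is tolerated, a higher number that more compound is tolerated. Compound 1 `O=C1c2ccccc2C(=O)N1CCOC(=S)N(C(=O)c1cccc([N+](=O)[O-])c1)c1ccc(Cl)cc1` gives 18000 nM. Compound 2 `Cc1ccc(N(C(=O)c2cccc([N+](=O)[O-])c2)C(=S)OCCN2C(=O)c3ccccc3C2=O)cc1` carries a methyl in place of chloro on an aromatic carbon, and gives 100000 nM; the step is a 5.6-fold higher number from compound 1 to compound 2 (0.74 log units; beyond the scatter). Compound 3 `O=C1c2ccccc2C(=O)N1CCOC(=S)N(C(=O)c1cccc(Cl)c1Cl)c1ccc(Cl)cc1` carries a 2,3-dichlorophenyl in place of 3-nitrophenyl on a carbonyl carbon, and gives 54000 nM; the step is a 3.0-fold higher number from compound 1 to compound 3 (0.48 log units; beyond the scatter). Compound 2 thus shows the highest of the three numbers, though its gap to compound 3 lies within the scatter, so no order between those two can be claimed.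

Compound 4 `Cc1ccc(N(C(=O)c2ccc(Cl)cc2Cl)C(=S)OCCN2C(=O)c3ccccc3C2=O)cc1` has not yet been measured. It differs from compound 2 in one place: 2,4-dichlorophenyl in place of 3-nitrophenyl on a carbonyl carbon. Among the measured compounds shown here, the closest precedent is a 3.0-fold higher number from compound 1 to compound 3 (0.48 log units; beyond the scatter), where a dichlorophenyl likewise replaced the 3-nitrophenyl. A rise of similar size, or none beyond the scatter, is expected here, because compound 2 already gives 100000 nM. Compound 4 is therefore estimated at 100000 nM, between 40000 nM and 250000 nM. The expected step is no change at the digits printed from compound 2 to compound 4 (within the scatter).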

Compound 4, half-maximal cytotoxic concentration: 49000 nM
Beside the measured number, compound 4's estimate is 2.0-fold (0.31 log units) above it; the range from low to high includes it.
By their numbers in this assay, from the lowest: compound 1; then compounds 4, 3 and 2 (each within the scatter of the next, the first and the last beyond it).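

In this assay, replacing the 3-nitrophenyl with a dichlorophenyl on the carbonyl carbon does not shift the number in one fixed direction: the earlier swap raised it (a 3.0-fold higher number from compound 1 to compound 3 (0.48 log units; beyond the scatter)), whereas this one lowers it (a 2.0-fold lower number from compound 2 to compound 4 (0.31 log units; beyond the scatter)). The two swaps differ in the entering group, 2,3-dichlorophenyl against 2,4-dichlorophenyl, and in the methyl or chloro carried elsewhere on the molecule, so this pair of steps cannot show which difference matters. Nothing available explains the reversal.

Still open, on these data alone, is whether the same dichlorophenyl would move the number the same way with both the methyl and the chloro. As far as these compounds go, it is also open how this carbonyl position responds to a group of another kind, such as an unsubstituted phenyl or a phenyl carrying an amine or a carboxylic acid.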